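Adding fluorine to the cyclopentyl ring of compound 3

This account rests on a few compounds, and the source may have more. Where it says the series, first, only, none or still open, it means among the compounds named here.

In a physicochemical assay for solubility, using the shake flask method, measured as kinetic solubility, with a stated time of 20 h, at pH 2 (on this read-out lower numbers stand for lower solubility and higher numbers for higher solubility), compound 1 `FC(F)(F)c1ccc(Nc2cc3[nH]c(-c4cccc(C(F)(F)F)c4)nc3cn2)nc1` reaches only a limit of the assay, < 5000 nM. Compound 2 `Fc1ccc(-c2nc3cnc(Nc4ccc(C(F)(F)F)cn4)cc3[nH]2)cc1F` gives 6000 nM. Compound 3 `FC(F)(F)c1ccc(Nc2cc3[nH]c(C4CCCC4)nc3cn2)nc1` gives 132000 nM, the highest number in this set.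

Compound 4 `FC1(F)CCC(c2nc3cnc(Nc4ccc(C(F)(F)F)cn4)cc3[nH]2)C1` differs from compound 3 by 3,3-difluorocyclopentyl in place of cyclopentyl on an aromatic carbon, with 3,3-difluorocyclopentyl in place of cyclopentyl. Two large measured steps bear on it, an at least 26-fold higher number from compound 1 to compound 3 (1.42 log units; beyond the scatter) and a 22-fold higher number from compound 2 to compound 3 (1.34 log units; beyond the scatter), both ending in cyclopentyl. Neither adds fluorine to that ring, so they guide the change only loosely. Compound 4 keeps the five-membered non-aromatic ring, so only a modest fall is expected, a 2.2-fold lower number from compound 3 to compound 4 (0.34 log units; beyond the scatter). Compound 4 is estimated at 60000 nM, within an expected range of 20000 nM to 170000 nM.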

Compound 4, solubility: 185000 nM
Compound 4: the middle estimate sits 3.1-fold (0.49 log units) below what was measured, and the stated range ends below it.
By their numbers in this assay, from the lowest: compound 2; then compounds 3 and 4 (each within the scatter of the next). At a limit, below all of these: compound 1.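

At this position, on an aromatic carbon between two ring nitrogen atoms, 3,3-difluorocyclopentyl in place of cyclopentyl cannot be told apart from the parent in this assay: a 1.4-fold higher number from compound 3 to compound 4 (0.15 log units; within the scatter). The large gain of the non-aromatic ring over the aromatic substituents therefore survives fluorination, with a 31-fold higher number from compound 2 to compound 4 (1.49 log units; beyond the scatter) and an at least 37-fold higher number from compound 1 to compound 4 (1.56 log units; beyond the scatter). The step from compound 1 starts from a limit of the assay, not a number: the limit of < 5000 nM in this assay, at which 1 of the 4 values shown sits.

On these data alone, what an amine or a hydroxyl group on the cyclopentyl ring would do in this assay remains open.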